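Replacing a terminal carboxy on the glycine amide of compound 3

The source may hold more compounds than are shown below. What is called first, only, known or untested is meant among the compounds shown, and "the series" means these compounds.

Compound 3, `CCCCCN(CCCCC)C(=O)N1CCN(C(=O)N(c2ccccc2)c2ccccc2)[C@H](C(=O)NCC(=O)O)C1`, stands highest of the three measured numbers in an assay on CHO cells for binding affinity to Substance-P receptor (Homo sapiens) (on this read-out lower numbers stand for stronger inhibition and higher numbers for weaker inhibition), where compound 3 gives 597 nM. Its nearest neighbour is compound 2, `CCCCCN(CCCCC)C(=O)N1CCN(C(=O)N(c2ccccc2)c2ccccc2)[C@H](CO)C1`, which gives 280 nM; the furthest is compound 1, `CCCCCN(CCCCC)C(=O)N1CCN(C(=O)N(c2ccccc2)c2ccccc2)[C@H](C(=O)O)C1`, which gives 130 nM. The measured steps show a 2.2-fold higher number from compound 1 to compound 2 (0.33 log units; beyond the scatter), a 4.6-fold higher number from compound 1 to compound 3 (0.66 log units; beyond the scatter) and a 2.1-fold higher number from compound 2 to compound 3 (0.33 log units; beyond the scatter).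

Compound 4, `CCCCCN(CCCCC)C(=O)N1CCN(C(=O)N(c2ccccc2)c2ccccc2)[C@H](C(=O)NCCNC(C)=O)C1`, differs from compound 3 by acetamidomethyl in place of carboxy on a saturated chain carbon bound to an amide-type nitrogen. Going by the values given here, no measured step covers this exact exchange. The closest comparison is the step from compound 1 to compound 2, where a carboxy was also given up and the number rose modestly, and the step from compound 2 to compound 3, which added the carboxymethylcarbamoyl chain and again raised the number. Both suggest that losing the carboxy from compound 3 is unlikely to lower the number, so a further modest rise or no change beyond the scatter is expected. The estimated step is a 1.4-fold higher number from compound 3 to compound 4 (0.15 log units; within the scatter). Compound 4 is therefore expected to give 850 nM in this assay, within a range of 300 nM to 2500 nM.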

Compound 4, half-maximal inhibitory concentration: 140 nM
For compound 4 the middle estimate is 6.1-fold (0.78 log units) above the measured one; the whole stated range lies above it.
By their numbers in this assay, from the lowest: compounds 1, 4 and 2 (each within the scatter of the next, the first and the last beyond it); then compound 3.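

In this assay, going by these compounds alone, the carboxy at the end of the (carboxymethyl)carbamoyl chain proves dispensable: acetamidomethyl in its place gives a 4.3-fold lower number from compound 3 to compound 4 (0.63 log units; beyond the scatter), the first change that brings this chain's number down. The resulting (2-acetamidoethyl)carbamoyl group also gives a 1.1-fold higher number from compound 1 to compound 4 (0.03 log units; within the scatter) and a 2.0-fold lower number from compound 2 to compound 4 (0.30 log units; within the scatter), so among these compounds a carboxy is not needed to reach the level of compound 1, and its presence in compound 3 does not secure that level. Nothing available explains this result.

The compounds shown leave open whether the acetamido group contributes in its own right or whether removing the carboxy is enough, which a plain ethyl or a primary amine at this place would help to separate. A longer chain ending in the same acetamido group would show how far this position tolerates extension.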